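Inverting the stereocentre in a thiophene-linked fatty acid receptor agonist

A few compounds are considered here, and "the series" means these few. Any claim that something is new, unique, unknown or untested is made for them only; others in the source may bear on it.

Compounds measured so far in a functional assay on cells for agonist activity at Free fatty acid receptor 1 (Homo sapiens), read by calcium flux; on this read-out lower numbers stand for an effect already at smaller amounts and higher numbers for an effect only at larger amounts of compound:
compound 1, `CC#CC(CC(=O)O)c1ccc(OCc2cccc(-c3c(C)cccc3C)c2)s1`: 210 nM
compound 2, `CCO[C@H](CC(=O)O)c1ccc(OCc2cccc(-c3c(C)cccc3C)c2)s1`: 50 nM
compound 3, `CC#C[C@@H](CC(=O)O)c1ccc(OCc2cccc(-c3c(C)cc(OCCCS(C)(=O)=O)cc3C)c2)s1`: 81 nM

Compound 3 holds the second highest of the three numbers in this assay. Its nearest neighbour is compound 2, which sits within the scatter of it, while compound 1 lies beyond the scatter on the higher side. Among the compounds with values here, the only measured step that differs in one place is a 4.2-fold lower number from compound 1 to compound 2 (0.62 log units; beyond the scatter), and it concerns the substituent on the aromatic carbon, not the configuration.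

Compound 4, `CC#C[C@H](CC(=O)O)c1ccc(OCc2cccc(-c3c(C)cc(OCCCS(C)(=O)=O)cc3C)c2)s1`, is the mirror image of compound 3 at its single stereocentre: the two compounds have the same atoms and bonds and differ only in configuration as drawn: 1 of 1 stereo elements differ; a stereocentre at a saturated chain carbon is drawn R in compound 3 and S in compound 4. Within the data shown here, no measured pair shows what a change of configuration alone does, since compound 1 is drawn without any configuration and compounds 2 and 3 carry different groups. The step is therefore estimated from general experience with enantiomer pairs rather than from these data, and it is expected to raise the number, by a 9.9-fold higher number from compound 3 to compound 4 (0.99 log units; beyond the scatter), with a wide margin. Compound 4 is thus expected to give about 800 nM in this assay, with a range from 100 nM to 8000 nM.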

Compound 4, half-maximal effective concentration: 410 nM
For compound 4 the middle estimate is 2.0-fold (0.29 log units) above the measured one; the measured number falls inside the stated range.
By their numbers in this assay, from the lowest: compounds 2 and 3 (each within the scatter of the next); then compounds 1 and 4 (each within the scatter of the next).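

In this assay, within the data shown here, changing the saturated chain carbon from R to S gives a 5.1-fold higher number from compound 3 to compound 4 (0.70 log units; beyond the scatter), the first direct reading of what configuration alone does at this position. The R form drawn in compound 3 therefore gives the lower number of this pair, so the position distinguishes between the two arrangements, although the size of the step is modest. The step can be assigned to the stereocentre alone because nothing else separates the two structures: the fact that compounds 3 and 4 differ only in the configuration as drawn

On these data alone, it remains open whether configuration at this carbon matters as much when it carries the ethoxy group of compound 2, or when the methylsulfonyl-bearing propoxy chain shared by compound 3 and compound 4 is absent. Also open, as far as these compounds go, is how a cyclopropyl group or a nitrile would fare on this stereocentre in place of the alkyne.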